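Swapping a Chlorophenyl Arm for a Benzoxazole

The compounds below may be only part of what the source reports. "The series", "measured", "known", "first", "only" and "open" are said of these compounds alone.

Compound 1 `O=C(O)CCCSCCN1C(=O)CC[C@@H]1/C=C/[C@@H](O)Cc1cccc(-c2ccc3[nH]ccc3c2)c1`: 3500 nM
Compound 2 `O=C(O)CCCSCCN1C(=O)CC[C@@H]1/C=C/[C@@H](O)Cc1cccc(OCc2ccncc2)c1`: > 10000 nM
Compound 3 `O=C(O)c1csc(SCCN2C(=O)CC[C@@H]2/C=C/[C@@H](O)Cc2cccc(-c3ccc(Cl)cc3)c2)n1`: 1.7 nM

In an assay on CHO cells for displacement of a labelled ligand from prostaglandin E2 receptor EP2 subtype (Mus musculus), read by scintillation counting, with a stated time of 60 min (on this read-out lower numbers stand for stronger inhibition and higher numbers for weaker inhibition), compound 3 stands lowest of the two numbers shown, well below compound 1. The result for compound 2 is only a limit, namely (the limit of > 10000 nM in this assay, at which 1 of the 3 values shown sits). Among the measured compounds shown here, the single measured step, an at least 2.8-fold higher number from compound 1 to compound 2 (0.45 log units; beyond the scatter), shows that exchanging the group at this position can move the number noticeably. Compound 4 `Cc1cccc2oc(-c3cccc(C[C@H](O)/C=C/[C@H]4CCC(=O)N4CCSc4nc(C(=O)O)cs4)c3)nc12` carries 4-methyl-1,3-benzoxazol-2-yl in place of 4-chlorophenyl on an aromatic carbon. This exchange is not the measured one, so the guide is rough; one aromatic group replaces another, and a modest shift in this assay, or none beyond the scatter, is expected: a 1.8-fold higher number from compound 3 to compound 4 (0.25 log units; within the scatter). Compound 4 is therefore estimated at 3 nM, between 0.6 nM and 15 nM.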

Compound 4, inhibition constant: 22 nM
Beside the measured number, compound 4's estimate is 7.3-fold (0.87 log units) below it, outside the stated range (above it).
By their numbers in this assay, from the lowest: compound 3; then compound 4; then compound 1. At a limit, above all of these: compound 2.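

Replacing 4-chlorophenyl with 4-methyl-1,3-benzoxazol-2-yl gives a 13-fold higher number from compound 3 to compound 4 (1.11 log units; beyond the scatter) in this assay, so on this aromatic carbon one aromatic group cannot simply stand in for another. The entering group brings a second ring and hydrogen-bond acceptors, and compound 4 stays weaker than compound 3 with them in place. Nothing measured here accounts for a step of this size.

On these data alone, whether the hetero atoms of the ring or its methyl group drive the change stays open. A plain 1,3-benzoxazol-2-yl group and a 4-methylphenyl group at this position would help to separate the two.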